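Alkyl Variation at the Para Position of a Chalcone Series

The compounds below may be only part of what the source reports. "The series", "measured", "known", "first", "only" and "open" are said of these compounds alone.

Measured compounds:
Compound 1 `COc1ccc(/C=C/C(=O)c2ccc(OCCn3cc(CN4C(=O)/C=C/C(C)(C)C/C=C(\C)CC/C=C/4C)nn3)cc2O)cc1`: 2.06 ug/mL in a functional assay on HepG2 cells (Homo sapiens) for antiproliferative activity; on this read-out lower numbers stand for stronger inhibition and higher numbers for weaker inhibition
Compound 2 `C/C1=C\CC(C)(C)/C=C/C(=O)N(Cc2cn(CCOc3ccc(C(=O)/C=C/c4ccc(C)cc4)c(O)c3)nn2)/C(C)=C/CC1`: 0.87 ug/mL in this assay

Compound 2 holds the lowest number of the two in this assay; the step of a 2.4-fold lower number from compound 1 to compound 2 (0.37 log units; beyond the scatter) lies beyond the scatter. Compound 3 `C/C1=C\CC(C)(C)/C=C/C(=O)N(Cc2cn(CCOc3ccc(C(=O)/C=C/c4ccc(C(C)C)cc4)c(O)c3)nn2)/C(C)=C/CC1` differs from compound 2 by isopropyl in place of methyl on an aromatic carbon. For the measured compounds named here, no measured step covers a methyl-to-isopropyl exchange, so nothing in the data bears directly on it; the only measured step concerns a methoxy-to-methyl swap. The step of a 1.1-fold lower number from compound 2 to compound 3 (0.04 log units; within the scatter) is therefore expected to stay within the scatter. Compound 3 is estimated at 0.8 ug/mL, between 0.35 ug/mL and 1.9 ug/mL.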

Compound 3, half-maximal inhibitory concentration: 0.84 ug/mL
Beside the measured number, compound 3's estimate is 1.1-fold (0.02 log units) below it, and the stated range covers the measured number.
By their numbers in this assay, from the lowest: compounds 3 and 2 (each within the scatter of the next); then compound 1.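

In this assay the change from 4-methylphenyl to 4-isopropylphenyl gives a 1.0-fold lower number from compound 2 to compound 3 (0.02 log units; within the scatter) and so shows that this position accepts isopropyl as readily as methyl. Set against the methoxy group, isopropyl gives a 2.5-fold lower number from compound 1 to compound 3 (0.39 log units; beyond the scatter) and thus stands with methyl, apart from compound 1. No available evidence accounts for this. Still open, going by these compounds, is how a tert-butyl group, a longer chain such as hexyl, or an amine or carboxylic acid would fare at this position. On these data alone, whether the number stays level with still larger alkyl groups also remains unknown.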